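The compounds below may be only part of what the source reports. "The series", "measured", "known", "first", "only" and "open" are said of these compounds alone.

The compounds measured so far:
compound 1, `CS(=O)(=O)c1ccc(-c2cnc(N)c(-c3ccc(N)nc3)n2)cc1`: in an ADME assay on microsomes from liver (Mus musculus) for metabolic stability, read by LC-MS, using NADPH, with a stated time of 30 min, tested at 0.1 uM, in the presence of a further agent that is not named here (a higher number here means that more of the compound is left, a lower number that less of the compound is left), compound 1 gives > 90%, which is a limit of the assay.
compound 2, `Nc1ccc(-c2cnc(N)c(-c3ccc(N)nc3)n2)cn1`: in this assay compound 2 gives > 90%, also a limit.
compound 3, `Nc1ncc(-c2ccc(C(=O)N3CCC(O)CC3)cc2)nc1-c1ccc(C(F)(F)F)cc1`: in this assay compound 3 gives > 90%, again a limit.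

Compound 3 therefore stands at the ceiling of what the assay reports rather than at a number, and the same is true of the two other compounds, so that (the limit of > 90% in this assay, at which 3 of the 3 values shown sit). On the values shown, nothing separates the three.

Compound 4, `Nc1ncc(-c2ccc(C(=O)N3CC(O)C3)cc2)nc1-c1ccc(C(F)(F)F)cc1`, is not yet measured. It differs from compound 3 in one place: 3-hydroxyazetidin-1-yl in place of 4-hydroxypiperidin-1-yl on a carbonyl carbon. Going by the values given here, no pair of measured compounds differs in a single place, so no measured step shows how such a change moves the read-out. Since every value shown sits at the limit, the account expects no step beyond the usual scatter, and compound 4 is expected to come out at the limit as well. The estimate for compound 4 is 92%, with a range from 85% to 100%. That estimate means a step that the limit leaves unreadable from compound 3 to compound 4, expected to remain within the scatter.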

Compound 4, percent of the compound remaining: > 90%
Compound 4 ended at the assay's limit (the forecaster's own chance of this, stated with the estimate: 70%); the middle value lies beyond the limit too.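

No step can be read between compound 3 and compound 4 in this assay: the limit of > 90% in this assay, at which 4 of the 4 values shown sit. The compounds shown leave open how much of each actually remains, and so whether 3-hydroxyazetidin-1-yl in place of 4-hydroxypiperidin-1-yl changes the read-out at all.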